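The source may report more compounds than this note shows. Statements on the series, on what has been measured and on what is new or still open speak of the compounds shown alone.

Working notes on the series. Compound 1 is `CC(C)[C@H](NC(=O)COc1cccc2ccccc12)C(=O)N[C@@H](CC(=O)O)C(=O)CSc1nc(-c2ccccc2)cs1`. In a functional assay on Jurkat cells (Homo sapiens) for inhibition (on this read-out lower numbers stand for stronger inhibition and higher numbers for weaker inhibition), compound 1 gives only a limit, > 200000 nM. Compound 2 is `CC(C)[C@H](NC(=O)COc1cccc2ccccc12)C(=O)N[C@@H](CC(=O)O)C(=O)COc1ccnc(C(F)(F)F)n1`, and in this assay compound 2 gives 37000 nM. Compound 3 is `CC(C)[C@H](NC(=O)COc1cccc2ccccc12)C(=O)N[C@@H](CC(=O)O)C(=O)COc1nncc(Cl)c1Cl`. In this assay compound 3 likewise gives only a limit, > 200000 nM. Compound 3 therefore stands at the weak end of what has been measured, at the limit of > 200000 nM in this assay, at which 2 of the 3 values shown sit, together with compound 1. Of the three steps, an at least 5.4-fold lower number from compound 1 to compound 2 (0.73 log units; beyond the scatter) is the one readable move towards stronger inhibition, an at least 5.4-fold higher number from compound 2 to compound 3 (0.73 log units; beyond the scatter) is its counterpart back on the oxygen-linked side, and a step that the two limits leave unreadable from compound 1 to compound 3.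

Compound 4 is `CC(C)[C@H](NC(=O)COc1cccc2ccccc12)C(=O)N[C@@H](CC(=O)O)C(=O)COc1ncnc2ccccc12`. It differs from compound 3 by quinazolin-4-yl in place of 4,5-dichloropyridazin-3-yl on an oxygen on a saturated carbon. Going by the values given here, no measured step exchanges the heteroaryl on the oxygen for a fused one, so the only step bearing on this change is an at least 5.4-fold higher number from compound 2 to compound 3 (0.73 log units; beyond the scatter), which shows that the choice of heteroaryl at this place can shift the read-out by a modest amount in either direction. The step of an at least 2.0-fold lower number from compound 3 to compound 4 (0.30 log units; that floor lies within the scatter) is accordingly expected to be modest and towards stronger inhibition, without certainty that it leaves the limit. Compound 4 is estimated at 100000 nM, within 20000 nM to 300000 nM.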

Compound 4, half-maximal inhibitory concentration: > 200000 nM
Compound 4: no number, only a limit; the forecaster's own chance of this, stated with the estimate: 45%; middle value at least 2.0-fold (0.30 log units) away from the limit.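

In this assay compound 4 gives only a limit, > 200000 nM, so the fused quinazolin-4-yl on this oxygen does not bring the read-out to a number. Quinazolin-4-yl on the oxygen gives an at least 5.4-fold higher number from compound 2 to compound 4 (0.73 log units; beyond the scatter), so a second group in place of 2-(trifluoromethyl)pyrimidin-4-yl, this one with an added six-membered aromatic ring of carbon only, also gives a weaker result, and 2-(trifluoromethyl)pyrimidin-4-yl remains the only group at this place with a number. The steps among compound 1, compound 3 and compound 4 cannot be read, as each rests on two limits, and the weak end of the series has grown: the limit of > 200000 nM in this assay, at which 3 of the 4 values shown sit.

From the compounds shown here alone, it remains open whether the number of compound 2 depends on the trifluoromethyl or on the pyrimidin-4-yl ring carrying it, a question that a methyl group or a nitrile in place of trifluoromethyl, or the unsubstituted pyrimidin-4-yl, would address. Going by these compounds alone, also open is what the oxygen link contributes, as the only sulfanyl compound, compound 1, carries a different heteroaryl as well, so a (2-(trifluoromethyl)pyrimidin-4-yl)sulfanyl group would separate the two changes.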